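Chloro for Methyl on the Aryl Ring of Compound 2

The source may report more compounds than this note shows. Statements on the series, on what has been measured and on what is new or still open speak of the compounds shown alone.

Measured compounds:
Compound 1, `Fc1ccc(C2=NN(C3=NC(c4ccccc4)CS3)C(c3cccc4ccccc34)C2)cc1`: 22700 nM
Compound 2, `Cc1ccc(C2=NN(C3=NC(=O)CS3)C(c3cccc4ccccc34)C2)cc1`: 10000 nM
Compound 3, `Fc1ccc(C2=NN(C3=NC(c4ccccc4)CS3)C(c3ccc4ccccc4c3)C2)cc1`: 17300 nM

In a functional assay on BGC-823 cells (Homo sapiens) for inhibition, read by CCK-8 assay, with a stated time of 48 h (a lower number here means a stronger inhibitor, a higher number a weaker inhibitor), compound 2 gives 10000 nM, the lowest of the three numbers. Its nearest neighbour is compound 3, which in this assay gives 17300 nM, a gap that lies within the scatter, so no order between compound 2 and compound 3 can be read from these figures. Compound 1, with 22700 nM in this assay, sits beyond the scatter from compound 2. Among the measured compounds shown here, the only step between measured compounds that differ in one place is a 1.3-fold lower number from compound 1 to compound 3 (0.12 log units; within the scatter), and it concerns the placement of the naphthalenyl group, not the substituent on the six-membered aromatic ring.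

Compound 4, `O=C1CSC(N2N=C(c3ccc(Cl)cc3)CC2c2cccc3ccccc23)=N1`, differs from compound 2 by chloro in place of methyl on an aromatic carbon. For the measured compounds named here, no measured pair shares this change: compound 1 and compound 3 carry a fluoro group there, but they also differ from compound 2 in the phenyl group on the other ring, so they give no single-place guide. With nothing bearing on the change, the estimate for compound 4 is expected to be a step of a 1.1-fold lower number from compound 2 to compound 4 (0.05 log units; within the scatter), that is, no step beyond the scatter. Compound 4 is therefore expected to give 9000 nM, with a range from 3500 nM to 25000 nM.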

Compound 4, half-maximal inhibitory concentration: 16400 nM
Compound 4: the middle estimate sits 1.8-fold (0.26 log units) below what was measured; the range from low to high includes it.
By their numbers in this assay, from the lowest: compounds 2, 4, 3 and 1 (each within the scatter of the next, the first and the last beyond it).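

In this assay the change from 4-methylphenyl to 4-chlorophenyl reads as a 1.6-fold higher number from compound 2 to compound 4 (0.21 log units; within the scatter), so at this place, on an aromatic carbon para to a large group, methyl and chloro cannot be put in order from these figures. Among the compounds shown here, this is the first reading of a single change on this six-membered aromatic ring: the only earlier step concerned the placement of the naphthalenyl group, and compound 1 and compound 3, which carry fluoro here, also differ from compound 2 in the phenyl group on the other ring. For the compounds shown here, no measurement of any property of these groups bears on the result, so the figures give no account of the step.

The compounds shown leave open whether a group of another kind on this carbon, such as a methoxy group, a dimethylamino group or a carboxylic acid, would give a step beyond the scatter. They also leave open whether the exchange of methyl for chloro would read the same with naphthalen-2-yl in place of naphthalen-1-yl on the shared core.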